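From 3-cyanophenyl to 4-bromophenyl: an expected growth-inhibition step

A few compounds are considered here, and "the series" means these few. Any claim that something is new, unique, unknown or untested is made for them only; others in the source may bear on it.

Measured in a functional assay on HL-60 cells (Homo sapiens) for inhibition, read by MTT assay, with a stated time of 72 h, tested at 50 uM; on this read-out lower numbers stand for less inhibition of growth and higher numbers for more inhibition of growth at the one concentration tested
- Compound 1 `C=CCc1ccc(OCc2cn(-c3ccccc3Cl)nn2)c(O)c1` gives 43.2%
- Compound 2 `C=CCc1ccc(OCc2cn(-c3ccc(OC)cc3)nn2)c(O)c1` gives 38.9%
- Compound 3 `C=CCc1ccc(OCc2cn(-c3cccc(C#N)c3)nn2)c(O)c1` gives 30.9%

Compound 3 stands apart from one of the other two compounds but not from both. The data show a number 12.3 percentage points lower from compound 1 to compound 3 (beyond the scatter), and they also show a number 8 percentage points lower from compound 2 to compound 3 (within the scatter).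

Compound 4 `C=CCc1ccc(OCc2cn(-c3ccc(Br)cc3)nn2)c(O)c1` has not been measured yet. Its structural change is 4-bromophenyl in place of 3-cyanophenyl on an aromatic nitrogen, which means 4-bromophenyl in place of 3-cyanophenyl on an aromatic nitrogen.

All three measured steps swap groups at this same place. The two groups other than 3-cyanophenyl are hard to tell apart, as the data show a number 4.3 percentage points lower from compound 1 to compound 2 (within the scatter). A small rise in this assay is therefore expected on leaving 3-cyanophenyl, resting on compound 2 at 38.9% and compound 1 at 43.2%. The expected change is a number 7.1 percentage points higher from compound 3 to compound 4 (within the scatter). For compound 4 the estimated value is 38%, with an expected range from 28% to 48%.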

Compound 4, percent growth inhibition at one concentration: 25.6%
Estimate against measurement, compound 4: 12.4 percentage points above, and the stated range ends above it.
By their numbers in this assay, from the lowest: compounds 4, 3, 2 and 1 (each within the scatter of the next, the first and the last beyond it).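

In this assay 4-bromophenyl stands apart from two of the other groups on the aromatic nitrogen, with a number 13.3 percentage points lower from compound 2 to compound 4 (beyond the scatter) and a number 17.6 percentage points lower from compound 1 to compound 4 (beyond the scatter), whereas 3-cyanophenyl stood apart from only one. The step with bromo in place of methoxy on an aromatic carbon shows that changing this single group on the phenyl ring can be enough to move the number beyond the scatter, yet 4-bromophenyl cannot be told apart from 3-cyanophenyl, with a number 5.3 percentage points lower from compound 3 to compound 4 (within the scatter). Nothing available explains these steps.

Still open, from the compounds shown here alone, is whether an amine or a carboxylic acid on this phenyl ring, or a longer chain in place of the ring, would give numbers outside those seen so far. With one tested concentration, these compounds also leave open how growth inhibition would change at other concentrations.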